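Notes on compound 1 and the step to compound 4

The source may report more compounds than this note shows. Statements on the series, on what has been measured and on what is new or still open speak of the compounds shown alone.

Compound 1 `CCN(Cc1ccccn1)c1ccc(C(=O)N2CCc3ccc(OS(N)(=O)=O)cc3C2)cc1` stands highest of the three compounds measured in an assay on HEK293 cells for inhibition of Steryl-sulfatase (Homo sapiens), tested at 0.1 uM (on this read-out higher numbers stand for a stronger effect at the one concentration tested and lower numbers for a weaker effect), where compound 1 gives 42.5%. Compound 3 `CCN(Cc1cccc(Br)c1)c1cccc(C(=O)N2CCc3ccc(OS(N)(=O)=O)cc3C2)c1` comes nearest, giving 20.9% in this assay, a number that lies beyond the scatter below compound 1. Compound 2 `CCN(Cc1ccccc1)Cc1ccc(S(=O)(=O)N2CCc3ccc(OS(N)(=O)=O)cc3C2)cc1` lies furthest, giving 10% in this assay, also beyond the scatter below compound 1. For the measured compounds named here, no pair of these three compounds differs in one place only, so no single computed step exists among them.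

Compound 4 `CN(CCN1CCCCC1)c1ccc(C(=O)N2CCc3ccc(OS(N)(=O)=O)cc3C2)cc1` has not yet been measured. It differs from compound 1 in one place: methyl(2-(piperidin-1-yl)ethyl)amino in place of ethyl((pyridin-2-yl)methyl)amino on an aromatic carbon. The change sits on an aromatic carbon of a six-membered aromatic ring of carbon only, para to a large group, and the shared core is kept. Going by the values given here, with no measured step for comparison, the expectation rests on compound 1 alone, whose value of 42.5% in this assay is the anchor. A modest downward step is expected, a number 9.5 percentage points lower from compound 1 to compound 4 (within the scatter), with a real chance that it falls within the scatter. Compound 4 is estimated at 33% in this assay, with a range from 12% to 58%.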

Compound 4, a percentage reported as inhibition, at one concentration (the size of the read-out at that concentration, not a potency): 0.3%
Estimate against measurement, compound 4: 32.7 percentage points above, outside the stated range (below it).
By their numbers in this assay, from the lowest: compounds 4 and 2 (each within the scatter of the next); then compound 3; then compound 1.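

At this aromatic carbon, para to a large group, replacing ethyl((pyridin-2-yl)methyl)amino with methyl(2-(piperidin-1-yl)ethyl)amino gives in this assay the only single-place step shown, a number 42.2 percentage points lower from compound 1 to compound 4 (beyond the scatter) and so the position is not indifferent to the group it carries. The two groups match in heavy atoms, carbon and nitrogen counts, hydrogen-bond donors and acceptors, and net charge, so those counts do not separate compound 1 from compound 4; what differs is a six-membered aromatic ring with one hetero atom against a six-membered non-aromatic ring with one hetero atom, and how that ring is attached. No measurement here gives a reason for the drop.

The ring and the chain carrying it change together in this one step, so their shares in it remain unresolved. Also open, as far as these compounds go, is how a morpholine ring on the same ethyl chain, or a phenylmethyl group in place of the (pyridin-2-yl)methyl, would read in this assay at this position.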